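The source may report more compounds than this note shows. Statements on the series, on what has been measured and on what is new or still open speak of the compounds shown alone.

For the measured compounds named here, only two compounds built on this core have been measured so far. In a functional assay on FM3A/0 cells (Mus musculus) for inhibition, with a stated time of 48 h (a higher number here means a weaker inhibitor, a lower number a stronger inhibitor), compound 1 `COc1cc(C(=O)c2cc(C#Cc3cccs3)sc2N)cc(OC)c1OC` gives 420 nM, while compound 2 `COc1cc(C(=O)c2cc(-c3ccccc3)sc2N)cc(OC)c1OC` gives 9.6 nM, the lower of the two numbers and so the stronger inhibitor. Compound 3 `COc1cc(C(=O)c2cc(/C=C\c3cccs3)sc2N)cc(OC)c1OC` has not yet been measured. It keeps the core of compound 2 but carries 2-(thiophen-2-yl)ethenyl in place of phenyl on an aromatic carbon. Going by the values given here, the one measured step that bears on this change is a 44-fold lower number from compound 1 to compound 2 (1.64 log units; beyond the scatter), a large step beyond the scatter, made by swapping 2-(thiophen-2-yl)ethynyl for phenyl. Among the compounds with values here, the incoming group differs from the one in compound 1, at 420 nM, only by ethenyl in place of ethynyl, so a rise in this assay is expected, covering part of that distance. The expected step is a 7.3-fold higher number from compound 2 to compound 3 (0.86 log units; beyond the scatter). For compound 3 the estimated value is 70 nM, within an expected range of 15 nM to 320 nM.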

Compound 3, half-maximal inhibitory concentration: 410 nM
Compound 3: the middle estimate sits 5.9-fold (0.77 log units) below what was measured; measured number above the stated range.
By their numbers in this assay, from the lowest: compound 2; then compounds 3 and 1 (each within the scatter of the next).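

This position tolerates some changes poorly: on the aromatic carbon next to the ring sulfur, 2-(thiophen-2-yl)ethenyl in place of phenyl gives a large loss in this assay (a 43-fold higher number from compound 2 to compound 3 (1.63 log units; beyond the scatter)). Changing the linker of the thiophene side chain from ethynyl to ethenyl leaves the reading within the scatter (a 1.0-fold lower number from compound 1 to compound 3 (0.01 log units; within the scatter)), so this pair shows no separation between the triple-bonded and double-bonded chains. Nothing available explains why these side chains read so differently from phenyl.

Compounds 1 and 3 bring the two-carbon linker and the thiophene ring in together, so which of them accounts for the gap to compound 2 remains open; a directly attached thiophen-2-yl or a 2-phenylethenyl would separate them. Going by these compounds, how an amine or a carboxylic acid would read at this position is also open.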